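Aryl replacement on the hydrazide carbonyl of compound 1

This account rests on a few compounds, and the source may have more. Where it says the series, first, only, none or still open, it means among the compounds named here.

Measured so far:
compound 1 `CC(C)(C)N(NC(=O)c1ccccc1I)C(=O)c1ccccc1Cl`: 1290 nM
compound 2 `Cc1cccc(C(=O)NN(C(=O)c2ccccc2Cl)C(C)(C)C)c1`: 603 nM

Compound 1 stands highest of the two numbers in an assay on cells for agonist activity at ecdysone receptor (Bombyx mori), read by a luciferase reporter, with a stated time of 24 h; on this read-out higher numbers stand for an effect only at larger amounts of compound and lower numbers for an effect already at smaller amounts; its nearest neighbour is compound 2, reached by the step of a 2.1-fold lower number from compound 1 to compound 2 (0.33 log units; beyond the scatter), a modest move beyond the scatter. Compound 3 `Cc1ccc(C)c(C(=O)NN(C(=O)c2ccccc2Cl)C(C)(C)C)c1` is not yet measured in this assay. It differs from compound 1 as follows: 2,5-dimethylphenyl in place of 2-iodophenyl on a carbonyl carbon. Going by the values given here, the only step that bears on this change is the one from compound 1 to compound 2, where a methylphenyl group also replaced the 2-iodophenyl group on the same carbonyl carbon and the number fell modestly. A step of similar size and direction is therefore expected for compound 3, with some room on both sides since a second methyl group is added. Compound 3 is estimated at 550 nM in this assay, in the range 200 nM to 1500 nM, which corresponds to the expected step of a 2.3-fold lower number from compound 1 to compound 3 (0.37 log units; beyond the scatter).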

Compound 3, half-maximal effective concentration: 1620 nM
Estimate against measurement, compound 3: 2.9-fold (0.47 log units) below; the measured number lies above the stated range.
By their numbers in this assay, from the lowest: compound 2; then compounds 1 and 3 (each within the scatter of the next).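

In this assay the added methyl does not carry the earlier drop further: methyl in place of hydrogen on an aromatic carbon gives a clear move the other way (a 2.7-fold higher number from compound 2 to compound 3 (0.43 log units; beyond the scatter)). The exchange of 2-iodophenyl for 2,5-dimethylphenyl on a carbonyl carbon gives a difference that cannot be told from scatter (a 1.3-fold higher number from compound 1 to compound 3 (0.10 log units; within the scatter)), so a methyl-bearing aryl group here does not by itself lower the number, and the pattern of substitution on that ring matters among these three compounds. Nothing at hand accounts for this reversal.

Still open, from the compounds shown here alone, is how this position responds to a group other than a halogen or methyl, such as an amine, a carboxylic acid or a methoxy group. Also open, going by these compounds, is whether the same methyl step holds when the rest of the shared core changes.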